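The source may report more compounds than this note shows. Statements on the series, on what has been measured and on what is new or still open speak of the compounds shown alone.

Working notes on the series.

Compound 1 `Nc1cc(-c2ccccc2)nc2ccc(NC(=O)/C=C/c3ccc(C(F)(F)F)cc3)cc12` is the weakest of the three measured compounds: in a functional assay on HEK293 cells for activation of melanin-concentrating hormone receptor 1 (Homo sapiens), read by inositol phosphate accumulation (a lower number here means that less compound is needed, a higher number that more compound is needed for the effect), compound 1 gives 6600 nM. Compound 2 `CCCc1cc(N)c2cc(NC(=O)/C=C/c3ccc(SC)cc3)ccc2n1` gives 71 nM and compound 3 `CCCc1cc(N)c2cc(NC(=O)/C=C/c3ccc(CC)cc3)ccc2n1` gives 160 nM, so compound 1 sits far above both, and the step from compound 1 to compound 3 is the smaller of its two gaps.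

Among the compounds with values here, the only step between single-point neighbours, a 2.3-fold higher number from compound 2 to compound 3 (0.35 log units; beyond the scatter), concerns the group on the cinnamamide ring and does not touch the position changed here. Within the data shown here, compounds 2 and 3 differ from compound 1 in two places at once, propyl where compound 1 carries phenyl and a different group on the cinnamamide ring, so no single step isolates the effect of the group beside the ring nitrogen of the shared core.

Compound 4 `Nc1cc(C2CCCCC2)nc2ccc(NC(=O)/C=C/c3ccc(C(F)(F)F)cc3)cc12` is compound 1 with cyclohexyl in place of phenyl on an aromatic carbon. The entering group is a non-aromatic ring, as the propyl of compounds 2 and 3 is non-aromatic, and those two compounds sit far below compound 1; on that thin basis a lower number is expected, but the size is uncertain. Compound 4 is estimated at 1500 nM, within 300 nM to 6000 nM, an expected step of a 4.4-fold lower number from compound 1 to compound 4 (0.64 log units; beyond the scatter).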

Compound 4, half-maximal effective concentration: 96 nM
Compound 4: the middle estimate sits 16-fold (1.19 log units) above what was measured; measured number outside the range, below it.
By their numbers in this assay, from the lowest: compounds 2, 4 and 3 (each within the scatter of the next, the first and the last beyond it); then compound 1.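

In this assay, the group next to the ring nitrogen is now isolated from the rest of the structure: the exchange of phenyl for cyclohexyl, with the trifluoromethyl on the cinnamamide ring held fixed, gives a 69-fold lower number from compound 1 to compound 4 (1.84 log units; beyond the scatter). The two groups have the same count of heavy atoms, all carbon, and each is a six-membered ring. The computed difference between them is an aromatic ring leaving and a non-aromatic ring entering, and this position proves highly sensitive to that one exchange. Nothing available explains the size of the step, which stands as an observation only.

Going by these compounds, it remains open whether the lower number belongs to cyclohexyl itself or extends to other non-aromatic groups at this position, such as cyclopentyl, piperidine or a propyl chain, on the core of compound 1 with its trifluoromethyl. On these data alone, it also remains open whether the same exchange gives a step of similar size when methylsulfanyl or ethyl sits on the cinnamamide ring.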